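This account rests on a few compounds, and the source may have more. Where it says the series, first, only, none or still open, it means among the compounds named here.

The series shares one core. Compound 1 `CCOC(=O)c1csc(-c2csc(-c3csc([C@@H](C)NC(=O)OC(C)(C)C)n3)n2)n1`, compound 2 `C[C@@H](NC(=O)OC(C)(C)C)c1nc(-c2nc(-c3nc(C(N)=O)cs3)cs2)cs1` and compound 3 `C[C@H](NC(=O)OC(C)(C)C)c1nc(-c2nc(-c3nc(C(N)=O)cs3)cs2)cs1` have each been tested in a functional assay on HCT-116 cells (Homo sapiens) for inhibition, read by CCK-8 assay, tested at 50 uM; a higher number here means more inhibition at the concentration tested (going by the name of the read-out), a lower number less inhibition. In this assay compound 1 is recorded only as "active" (no number reported), without a number. In this assay compound 2 gives 70%, and compound 3 gives 70%. Compound 2 therefore stands level with compound 3 at the digits reported, and the step of no change at the digits printed from compound 2 to compound 3 (within the scatter) lies within the scatter, which fits the fact that compounds 2 and 3 differ only in the configuration as drawn: the two share every atom and bond and differ only in the configuration drawn at the stereocentre on the saturated chain carbon.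

Compound 4 `C[C@@H](NC(=O)OC(C)(C)C)c1nc(-c2nc(-c3nc(C(N)=S)cs3)cs2)cs1` has not yet been measured. It differs from compound 2 in one place: a group of 3 heavy atoms (1 carbon, 1 nitrogen, 1 sulfur; no ring) in place of a group of 3 heavy atoms (1 carbon, 1 nitrogen, 1 oxygen; no ring), on an aromatic carbon. Going by the values given here, none of the measured steps touches this kind of change; the only recorded step, from compound 2 to compound 3, concerns configuration alone and lies within the scatter, so it gives no guide to the size or direction of exchanging one oxygen for one sulfur in that group. With nothing to lean on, the expectation is that compound 4 remains close to compound 2, so that no change at the digits printed from compound 2 to compound 4 (within the scatter) is expected to be small and not beyond the scatter in either direction. For compound 4 in this assay the estimate is 70%, expected to fall between 50% and 88%.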

Compound 4, a percentage reported as inhibition, at one concentration (the size of the read-out at that concentration, not a potency): 70%
Estimate against measurement, compound 4: no gap at the digits printed, within the range that was stated.
By their numbers in this assay, from the lowest: compounds 2, 3 and 4 (each within the scatter of the next).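

In this assay, going by these compounds alone, the exchange of the carbamoyl oxygen for sulfur, on the aromatic carbon next to the ring nitrogen, gives no change at the digits printed from compound 2 to compound 4 (within the scatter) and so provides the first reading of a change at this position rather than at the stereocentre on the saturated chain carbon. The group can therefore carry sulfur in place of oxygen, with the heavy-atom count and the counted hydrogen-bond donor and acceptor unchanged, without moving the read-out beyond the scatter at the single concentration tested, whereas compound 1, which carries an ethyl ester at this position, gives only "active" (no number reported) and offers no size for comparison. Nothing in the information available bears on why this exchange leaves the read-out level.

As far as these compounds go, how far the read-out stays level remains open, since a carboxylic acid, a nitrile or an amine on this aromatic carbon would test the position with a group of a different kind. Also open, from the compounds shown here alone, are whether the sulfur group would read the same with the configuration drawn in compound 3, and whether compound 2 and compound 4 would stay level in a full concentration series.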